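Trading Cyano for Bromo Beside the Shared Core

The compounds below may be only part of what the source reports. "The series", "measured", "known", "first", "only" and "open" are said of these compounds alone.

Of the compounds shown here, three have so far been measured in a functional assay on the whole organism for inhibition, with Rattus norvegicus as the target, at a dose of 30 mg/kg; on this read-out lower numbers stand for less inhibition and higher numbers for more inhibition at the one dose given (going by the name of the read-out). Compound 2 `N#Cc1ccccc1-c1nc2ncccc2o1` gives 62%, the highest of the three numbers. Compound 3 `COc1ccc(C#N)c(-c2nc3ncccc3o2)c1` gives 3%, and compound 1 `COc1ccc(Br)c(-c2nc3ncccc3o2)c1` gives 8%. Compound 4 `Brc1ccccc1-c1nc2ncccc2o1` is not yet measured in this assay.

Two of the measured pairs differ in one place each. Compound 3 and compound 1 differ as bromo in place of cyano on an aromatic carbon; that change produced a step of a number 5 percentage points higher from compound 3 to compound 1 (within the scatter). Compound 2 and compound 3 differ in their cores as hydrogen in place of methoxy on an aromatic carbon, and the step was a number 59 percentage points lower from compound 2 to compound 3 (beyond the scatter), a large one. The two cores of compound 2 and compound 3 are otherwise alike.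

The unmeasured compound 4 differs from compound 2 as bromo in place of cyano on an aromatic carbon. Among the compounds with values here, this is the same kind of change as the one from compound 3 to compound 1, but not the same: in the earlier pair the place is also para to a methoxy group (2 heavy atoms), which is absent in the pair of compound 2 and compound 4. The change occurs twice among the four compounds.

In this assay compound 4 is expected to move by about a number 12 percentage points lower from compound 2 to compound 4 (beyond the scatter), set beside the earlier step, which stayed within the scatter. That expectation rests on the small earlier step, with the caution that it started from a low number, since compound 3 gives only 3%. Compound 4 is therefore estimated at 50%, with a likely range from 20% to 78%.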

Compound 4, a percentage reported as inhibition, in the whole organism at one dose (the size of the read-out at that dose, not a potency): 24%
Estimate against measurement, compound 4: 26 percentage points above, within the range that was stated.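

In this assay, bromo in place of cyano on the core without the methoxy group gave a number 38 percentage points lower from compound 2 to compound 4 (beyond the scatter), so the change did not carry over unchanged from the core bearing the methoxy group: the same change on two cores in this assay, a number 5 percentage points higher (within the scatter) from compound 3 to compound 1 and a number 38 percentage points lower (beyond the scatter) from compound 2 to compound 4, 43 percentage points apart, beyond the scatter of two such steps The other change in the set also depended on its setting, since hydrogen in place of methoxy gave a number 16 percentage points higher from compound 1 to compound 4 (beyond the scatter) with bromo present, a step that differs from the one seen with cyano present: the same change on two cores in this assay, a number 59 percentage points lower (beyond the scatter) from compound 2 to compound 3 and a number 16 percentage points lower (beyond the scatter) from compound 4 to compound 1, 43 percentage points apart, beyond the scatter of two such steps These four compounds show that, within this one set, neither step can be taken from one core to the other, but they do not show why, and they give no rule for other cores, particularly as compound 3 gives only 3% and the earlier step starts from that low number.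

The compounds shown leave open whether any group other than bromo, such as an amine or a carboxylic acid, could stand in place of cyano and stay close to compound 2 at 62%. They also leave open what a longer chain in place of methoxy would do, and whether the gap between the steps would persist at another dose.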